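The compounds below may be only part of what the source reports. "The series", "measured", "known", "first", "only" and "open" are said of these compounds alone.

Measured in a functional assay on U-87MG ATCC cells for antiproliferative activity against U-87 MG (Homo sapiens), read by MTT assay; a higher number here means a weaker inhibitor, a lower number a stronger inhibitor:
- compound 1 `Cc1cc(=O)c(O)c(Cc2ccccc2)o1`: > 50000 nM (a limit)
- compound 2 `Cc1cc(=O)c(O)c(Cc2ccc(F)cc2)o1`: > 50000 nM (a limit)
- compound 3 `Cc1cc(=O)c(O)c(Cc2ccc(OCc3ccccc3)cc2)o1`: > 50000 nM (a limit)

In this assay, compound 3 stands at > 50000 nM, which is a limit and not a number. The whole series shares this position, at the limit of > 50000 nM in this assay, at which 3 of the 3 values shown sit.

Compound 4 `Cc1cc(=O)c(O)c(C(c2ccc(OCc3ccccc3)cc2)c2oc(C)cc(=O)c2O)o1` differs from compound 3 by a group of 9 heavy atoms (6 carbon, 3 oxygen; one six-membered aromatic ring with 1 hetero atom) in place of a hydrogen atom, on a saturated chain carbon bound to two aromatic carbons. Three measured steps form the background: a step that the two limits leave unreadable from compound 1 to compound 2, a step that the two limits leave unreadable from compound 1 to compound 3 and a step that the two limits leave unreadable from compound 2 to compound 3. None has a readable size, and each is a change on an aromatic carbon, not on the saturated chain carbon. They therefore give no measured guide to size or direction.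

The reasoning rests on a step that the two limits leave unreadable from compound 1 to compound 3, which shows no readable gain, so only a modest strengthening is expected, and another limit is about as likely as a number. The expected change is an at least 1.4-fold lower number from compound 3 to compound 4 (0.15 log units; that floor lies within the scatter). For compound 4 the estimated value is 35000 nM, with an expected range of 10000 nM to 80000 nM.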

Compound 4, half-maximal inhibitory concentration: 4600 nM
Estimate against measurement, compound 4: 7.6-fold (0.88 log units) above; measured number outside the range, below it.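

Putting the group of 9 heavy atoms, with its six-membered aromatic ring with 1 hetero atom, on the saturated chain carbon bound to two aromatic carbons gives an at least 10-fold lower number from compound 3 to compound 4 (1.03 log units; beyond the scatter) in this assay. Among these compounds, this is the first readable step: the earlier changes on an aromatic carbon, fluoro and benzyloxy in place of hydrogen, gave steps that cannot be read. The saturated chain carbon is therefore a place where a change can be measured in this assay, and compound 4 alone of the four has a number and not a limit: the limit of > 50000 nM in this assay, at which 3 of the 4 values shown sit.

The compounds shown leave open whether the same group on the saturated chain carbon would have a like effect with hydrogen or fluoro in place of benzyloxy on the aromatic carbon. They also leave open whether a simpler group there, such as a methyl or an amine, would move the number at all.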